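Replacing Bromo with Ethoxycarbonyl in an Antiproliferative Series

The source may report more compounds than this note shows. Statements on the series, on what has been measured and on what is new or still open speak of the compounds shown alone.

In a functional assay on MDA-MB-231 cells (Homo sapiens) for antiproliferative activity, read by MTT assay, with a stated time of 72 h (on this read-out higher numbers stand for weaker inhibition and lower numbers for stronger inhibition), compound 2 `O=C(CCc1cccc2c1B(O)OC2)Nc1ccc(Br)cc1` gives 5300 nM. Compound 1 `O=C(CCc1cccc2c1B(O)OC2)Nc1ccc(Cl)cc1` gives 3600 nM, and these two form the upper pair of the three numbers. Compound 3 `Cc1ccc(NC(=O)CCc2cccc3c2B(O)OC3)cc1` gives 1100 nM, clearly lower than both.

Compound 4 `CCOC(=O)c1ccc(NC(=O)CCc2cccc3c2B(O)OC3)cc1` has ethoxycarbonyl in place of bromo on an aromatic carbon, para to a large group: ethoxycarbonyl in place of bromo on an aromatic carbon. Three measured steps change the same place. The halogen exchange gives a 1.5-fold higher number from compound 1 to compound 2 (0.17 log units; within the scatter), while methyl gives a 3.3-fold lower number from compound 1 to compound 3 (0.51 log units; beyond the scatter) and a 4.8-fold lower number from compound 2 to compound 3 (0.68 log units; beyond the scatter). Among the measured compounds shown here, these steps span only small groups, and none of them introduces anything like ethoxycarbonyl, so the data offer no direct precedent. For the measured compounds named here, since the one exchange that moved the number beyond the scatter lowered it only modestly, a large step is not anticipated. The expected change is a 1.8-fold lower number from compound 2 to compound 4 (0.25 log units; within the scatter), which would not separate the two compounds beyond the scatter. For compound 4 the estimated value is 3000 nM, with an expected range of 1000 nM to 9000 nM.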

Compound 4, half-maximal inhibitory concentration: > 100000 nM
Compound 4: a limit, no number (the forecaster's own chance of this, stated with the estimate: 5%); middle value at least 33-fold (1.52 log units) from the limit.
By their numbers in this assay, from the lowest: compound 3; then compounds 1 and 2 (each within the scatter of the next). At a limit, above all of these: compound 4.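

In this assay compound 4 gives a limit of the assay and not a number: the limit of > 100000 nM in this assay, at which 1 of the 4 values shown sits. Even so, the change at this position is large, with an at least 18-fold higher number from compound 2 to compound 4 (1.27 log units; beyond the scatter), an at least 27-fold higher number from compound 1 to compound 4 (1.44 log units; beyond the scatter) and an at least 90-fold higher number from compound 3 to compound 4 (1.95 log units; beyond the scatter), whereas the earlier exchanges among chloro, bromo and methyl were modest at most. Among the compounds shown here, the position on the aromatic carbon, para to a large group, therefore accepts small groups but responds far more strongly to ethoxycarbonyl, the only group here that brings hydrogen-bond acceptors and a double bond outside aromatic rings.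

The compounds shown leave open whether this step belongs to the whole ester or to its ethyl part, which a carboxylic acid or a methyl ester at this place would address. They also leave open whether a small oxygen-bearing group such as methoxy, or an amine, would stay close to compound 3.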